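The compounds below may be only part of what the source reports. "The series", "measured", "known", "first", "only" and "open" are said of these compounds alone.

Measured so far in a functional assay on PC-3 cells (Homo sapiens) for cytotoxicity, read by sulforhodamine B assay, with a stated time of 5 days; a lower number here means a stronger inhibitor, a higher number a weaker inhibitor:
- compound 1, `O=C(CCCc1ccccc1)CC(=O)N[C@H]1CCOC1=O`, gives > 100000 nM; this is a limit of the assay.
- compound 2, `O=C(CCCCCCc1ccccc1)N[C@H]1CCOC1=O`, gives > 100000 nM; this is a limit.
- compound 3, `O=C(CCc1ccccc1)CC(=O)N[C@H]1CCOC1=O`, gives > 100000 nM; this is a limit.

Compound 1 therefore stands only at a limit of this assay, and the same holds for the other two compounds, as the evidence shows: the limit of > 100000 nM in this assay, at which 3 of the 3 values shown sit. Among the compounds with values here, the one measured step, a step that the two limits leave unreadable from compound 1 to compound 3, runs between two limits and its size cannot be read.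

Compound 4, `O=C(CCCCc1ccccc1)CC(=O)N[C@H]1CCOC1=O`, differs from compound 1 by benzyl in place of phenyl on a saturated chain carbon, three bonds along the chain from a carbonyl carbon. Within the data shown here, the measured step is the only one bearing on this change, and it gives no readable size or direction. The expectation for compound 4 is therefore another limit rather than a change beyond the scatter, with a number no higher from compound 1 to compound 4 (the limit leaves the size open) expected as essentially nil. Compound 4 is estimated at 100000 nM, with a range from 30000 nM to 300000 nM.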

Compound 4, half-maximal inhibitory concentration: 83000 nM
Beside the measured number, compound 4's estimate is 1.2-fold (0.08 log units) above it; the range from low to high includes it.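

In this assay, compound 4 is the first of the compounds shown to give a number rather than a limit, so this change at this place can be given a floor for the first time: the step is an at least 1.2-fold lower number from compound 1 to compound 4 (0.08 log units; that floor lies within the scatter). Its full size cannot be read. The remaining compounds shown still sit at a limit: the limit of > 100000 nM in this assay, at which 3 of the 4 values shown sit.

The compounds shown leave open whether a longer chain in place of benzyl would move the number beyond the scatter. They also leave open what an amine or a carboxylic acid at this place would give.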